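The compounds below may be only part of what the source reports. "The series", "measured", "known", "first", "only" and "open" are said of these compounds alone.

Working notes on the series. The compounds share a core carrying a diisopropyl-substituted aryl urea joined to a tetrazole, and differ in what sits on the ring nitrogen. Compound 1, `CC(C)c1cccc(C(C)C)c1NC(=O)Nc1nn[nH]n1`, carries hydrogen there. Compound 2, `CC(C)c1cccc(C(C)C)c1NC(=O)NC1=NN(Cc2ccccc2)NN1`, carries benzyl. Compound 3, `CCCCCCN1NN=C(NC(=O)Nc2c(C(C)C)cccc2C(C)C)N1`, carries hexyl. Compound 4, `CCCCCCCCCN1NN=C(NC(=O)Nc2c(C(C)C)cccc2C(C)C)N1`, carries nonyl and has not yet been measured.

In an assay on microsomes from intestine for inhibition of acyl-CoA:cholesterol acyltransferase (Oryctolagus cuniculus) (on this read-out higher numbers stand for weaker inhibition and lower numbers for stronger inhibition), compound 1 gives only a limit, > 10000 nM, which is the upper bound of what the assay reports (the limit of > 10000 nM in this assay, at which 1 of the 3 values shown sits). In this assay compound 2 gives 370 nM. Compound 3 gives 73 nM in this assay, the lowest of the two numbers in hand; the nearest is compound 2, whose number lies well beyond the scatter above it.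

The step to compound 4 is propyl in place of hydrogen on a saturated chain carbon, six bonds along the chain from an amine nitrogen in a ring. Within the data shown here, no measured pair in the set differs in exactly this way, so the direction has to be taken from the chain already present: compound 3 with hexyl sits below compound 2 and below the limit of compound 1, and an expectation of a modest further improvement, or no change beyond the scatter, seems reasonable. The expected step of a 1.5-fold lower number from compound 3 to compound 4 (0.16 log units; within the scatter) is small. For compound 4 the estimate in this assay is 50 nM, with a range from 15 nM to 200 nM.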

Compound 4, half-maximal inhibitory concentration: 31 nM
Beside the measured number, compound 4's estimate is 1.6-fold (0.21 log units) above it; the measured number falls inside the stated range.
By their numbers in this assay, from the lowest: compound 4; then compound 3; then compound 2. At a limit, above all of these: compound 1.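

In this assay, among these compounds, the change from hexyl to nonyl, propyl in place of hydrogen on a saturated chain carbon, six bonds along the chain from an amine nitrogen in a ring, gives a 2.4-fold lower number from compound 3 to compound 4 (0.37 log units; beyond the scatter), the only step that can be read between two compounds differing in one place. The number at this position therefore still moves when the chain grows past hexyl, and the entering propyl, which brings no ring and no hydrogen-bond donors or acceptors, is enough for a modest step. No measurement in hand gives a reason for this step.

Going by these compounds, a single step fixes a direction over one stretch of chain only, so whether a longer chain such as dodecyl would lower the number further, level off or raise it remains open. Also open, on these data alone, is whether this position accepts a branched chain, or a carboxylic acid or an amine at the chain end, in place of the plain nonyl.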